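A few compounds are considered here, and "the series" means these few. Any claim that something is new, unique, unknown or untested is made for them only; others in the source may bear on it.

Measured compounds:
compound 1 `CC1=C(C(C)C(=O)NCCN(C)C)c2cc(F)ccc2/C1=C\c1ccc([S+](C)[O-])cc1` — > 50000 nM (a limit)
compound 2 `CC1=C(C(C)C(=O)N(CCNC(C)C)C(C)C)c2cc(F)ccc2/C1=C\c1ccc([S+](C)[O-])cc1` — 21300 nM
compound 3 `CC1=C(C(C)C(=O)N2CCN(CCN(C)C)CC2)c2cc(F)ccc2/C1=C\c1ccc([S+](C)[O-])cc1` — > 50000 nM (a limit)

All three share one core and differ only in the group on the carbonyl carbon. In a functional assay on MDA-MB-231 cells (Homo sapiens) for inhibition, read by CellTiter-Glo, with a stated time of 96 h (on this read-out lower numbers stand for higher toxicity in this test and higher numbers for lower toxicity in this test), compound 1 reached only the limit > 50000 nM. Compound 2 gave a number, 21300 nM. Compound 3 again reached the limit > 50000 nM, so its position is known only as a limit. Two of the three values sit at that limit (the limit of > 50000 nM in this assay, at which 2 of the 3 values shown sit), which leaves a step that the two limits leave unreadable from compound 1 to compound 3, while an at least 2.3-fold higher number from compound 2 to compound 3 (0.37 log units; beyond the scatter).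

Compound 4 `CC1=C(C(C)C(=O)N2CCN(CCCN(C)C)CC2)c2cc(F)ccc2/C1=C\c1ccc([S+](C)[O-])cc1` differs from compound 3 by (dimethylamino)methyl in place of dimethylamino on a saturated chain carbon, two bonds along the chain from an amine nitrogen in a ring. For the measured compounds named here, none of the measured steps touches this part of the molecule; they swap the whole group on the carbonyl carbon instead, so they give no direct guide. Since compound 3 already stands at the limit, compound 4 is expected to show a step that the limit leaves unreadable from compound 3 to compound 4, that is, no step beyond the scatter. Compound 4 is therefore estimated at 60000 nM, between 20000 nM and 200000 nM.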

Compound 4, half-maximal cytotoxic concentration: > 50000 nM
Compound 4 gave a limit, no number (the forecaster's own chance of this, stated with the estimate: 80%); the middle value does not contradict the limit.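

In this assay compound 4, which carries 4-(3-(dimethylamino)propyl)piperazin-1-yl on the carbonyl carbon, gives > 50000 nM, and this is a limit, not a number. Set against the isopropyl(2-(isopropylamino)ethyl)amino group, the new group shows an at least 2.3-fold higher number from compound 2 to compound 4 (0.37 log units; beyond the scatter), so lengthening the chain at this position does not bring the value into the range of compound 2. The steps to compound 4 from compound 1 and compound 3 cannot be read, and any effect of (dimethylamino)methyl in place of dimethylamino stays hidden, because those values all sit at one limit: the limit of > 50000 nM in this assay, at which 3 of the 4 values shown sit.

Going by these compounds, only compound 2 gives a number, so it remains open whether this position matters at all where values can be read. Also open, on these data alone, is whether a still longer chain ending in dimethylamino, or a chain ending in a primary amine, would give a number.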